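The compounds below may be only part of what the source reports. "The series", "measured", "known", "first", "only" and "open" are said of these compounds alone.

Compound 1 `Cc1cc(OCC(=O)O)cc(C)c1Cl` stands beside two compounds that share a different core, compound 2 `O=C(O)CSc1ccc(Cl)cc1` and compound 3 `O=C(O)CSc1ccc(Br)cc1`. How the core of compound 1 differs from the core of compound 2 is not broken down here. In an ADME assay for solubility (a higher number here means a more soluble compound, a lower number a less soluble compound), compound 1 gives 239000 ug/mL. In this assay compound 2 gives 231000 ug/mL, and compound 3 gives 231000 ug/mL; these three numbers lie within the usual scatter of one another.

Compound 3 differs from compound 2 by one change (bromo in place of chloro on an aromatic carbon), and the measured step is no change at the digits printed from compound 2 to compound 3 (within the scatter). Compound 4 `Cc1cc(OCC(=O)O)cc(C)c1Br` has not yet been measured; it differs from compound 1 by a change of the same kind (bromo in place of chloro on an aromatic carbon). The two surroundings are not identical: in compound 1 the carbon carrying the halogen is ortho to two methyl groups, which is not the case in compound 2, so the change is of the same kind rather than the same.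

Among the compounds with values here, on the single measured instance of the change, compound 4 is expected to give an estimate of 230000 ug/mL in this assay, between 120000 ug/mL and 450000 ug/mL. This expectation rests on the step of no change at the digits printed from compound 2 to compound 3 (within the scatter) and on the value of compound 1, 239000 ug/mL, and the estimated step of a 1.0-fold lower number from compound 1 to compound 4 (0.02 log units; within the scatter) is expected to lie within the scatter. The measurement itself remains to be seen.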

Compound 4, solubility: 239000 ug/mL
Estimate against measurement, compound 4: 1.0-fold (0.02 log units) below; the range from low to high includes it.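

With bromo in place of chloro on an aromatic carbon ortho to two methyl groups, this assay shows no change at the digits printed from compound 1 to compound 4 (within the scatter). Set beside the earlier instance of the same change, the step carries over from one core to the other without a measurable difference: the same change on two cores in this assay, no change at the digits printed (within the scatter) from compound 2 to compound 3 and no change at the digits printed (within the scatter) from compound 1 to compound 4, 1.0-fold (0.00 log units) apart, within the scatter of two such steps. This shows that, for these two pairs, a reading of the change on one core gave a fair guide to the other, even though the halogen has two methyl groups flanking it only in compound 1 and compound 4, but it rests on just two instances and does not establish a rule for the whole series, nor does it say how the change would behave on any further core or in any other measurement.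

All four compounds shown carry a carboxylic acid and a single chloro or bromo group, and the two pairs give no reading of what fluoro or iodo would do in that place. As far as these compounds go, it also remains open whether the same swap would stay as quiet in compounds where an amide or an amine stands in place of the carboxylic acid, or where a longer chain links the acid to the aromatic ring.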